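Truncated Analogue of a Limit-Bound Pair

The compounds below may be only part of what the source reports. "The series", "measured", "known", "first", "only" and "open" are said of these compounds alone.

Compound 1 `CC(C)=CCC[C@H](C)c1ccc(C)c(CNCCCCCO)c1O` and compound 2 `CC(C)=CCC[C@H](C)c1ccc(C)c(CNCCCCC(=O)O)c1O` differ only by carboxy in place of hydroxymethyl on a saturated chain carbon, four bonds along the chain from an amine nitrogen. In a functional assay on MDA-MB-231 cells (Homo sapiens), read by wound healing assay, with a stated time of 24 h (a lower number here means a stronger inhibitor, a higher number a weaker inhibitor), compound 1 gives > 20000 nM, a limit of the assay. In this assay compound 2 gives > 20000 nM, also a limit. The step that the two limits leave unreadable from compound 1 to compound 2 cannot be read because both values sit at the limit of > 20000 nM in this assay, at which 2 of the 2 values shown sit. Compound 3 `CC(C)=CCC[C@H](C)c1ccc(C)c(CO)c1O` differs from compound 2 by hydroxy in place of (4-carboxybutyl)amino on a saturated chain carbon bound to an aromatic carbon. Going by the values given here, no measured step bears on this change. Compound 3 is therefore expected to remain at the limit, with a step that the limit leaves unreadable from compound 2 to compound 3 of no readable size. Compound 3 is estimated at 30000 nM, between 8000 nM and 120000 nM.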

Compound 3, half-maximal inhibitory concentration: 12300 nM
Estimate against measurement, compound 3: 2.4-fold (0.39 log units) above; low and high end bracket the measured number.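

In this assay compound 3 gives 12300 nM, a readable number on the saturated chain carbon bound to an aromatic carbon. Hydroxy in place of either amino chain gives an at least 1.6-fold lower number from compound 2 to compound 3 (0.21 log units; that floor lies within the scatter) and an at least 1.6-fold lower number from compound 1 to compound 3 (0.21 log units; that floor lies within the scatter). Going by these compounds, both steps are floors, so their true size is unknown, and neither floor alone shows a change beyond the scatter. The other two compounds give no number to measure from: the limit of > 20000 nM in this assay, at which 2 of the 3 values shown sit.

On these data alone, how a methoxy group or a plain amino group on this carbon would read in this assay stays open. So does the effect of a shorter chain on the amine nitrogen.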